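Aryl ether substituent change on the shared core

This account rests on a few compounds, and the source may have more. Where it says the series, first, only, none or still open, it means among the compounds named here.

Compound 1 `CC[C@@H]1/C=C(\C)C[C@H](C)C[C@H](OC)[C@H]2O[C@@](O)(C(=O)C(=O)N3CCCC[C@H]3C(=O)O[C@H](/C(C)=C/[C@@H]3CC[C@@H](Oc4ccc(F)cc4)[C@H](OC)C3)[C@H](C)[C@@H](O)CC1=O)[C@H](C)C[C@@H]2OC` gives 3.4 nM in a functional assay on cells for inhibition, with Murine T-cell line (Mus musculus) as the target (on this read-out lower numbers stand for stronger inhibition and higher numbers for weaker inhibition), the highest number among the three measured compounds. Compound 3 `CC[C@@H]1/C=C(\C)C[C@H](C)C[C@H](OC)[C@H]2O[C@@](O)(C(=O)C(=O)N3CCCC[C@H]3C(=O)O[C@H](/C(C)=C/[C@@H]3CC[C@@H](O)[C@H](Oc4ccccc4)C3)[C@H](C)[C@@H](O)CC1=O)[C@H](C)C[C@@H]2OC` gives 3.2 nM in this assay, within the scatter of compound 1. Compound 2 `CC[C@@H]1/C=C(\C)C[C@H](C)C[C@H](OC)[C@H]2O[C@@](O)(C(=O)C(=O)N3CCCC[C@H]3C(=O)O[C@H](/C(C)=C/[C@@H]3CC[C@@H](Oc4ccc(O)cc4)[C@H](O)C3)[C@H](C)[C@@H](O)CC1=O)[C@H](C)C[C@@H]2OC` gives 1.6 nM in this assay, a lower number than compound 1 by a gap beyond the scatter. Compound 4 `CC[C@@H]1/C=C(\C)C[C@H](C)C[C@H](OC)[C@H]2O[C@@](O)(C(=O)C(=O)N3CCCC[C@H]3C(=O)O[C@H](/C(C)=C/[C@@H]3CC[C@@H](Oc4ccc(SC)cc4)[C@H](OC)C3)[C@H](C)[C@@H](O)CC1=O)[C@H](C)C[C@@H]2OC` differs from compound 1 by methylsulfanyl in place of fluoro on an aromatic carbon, the 4-fluorophenoxy becoming 4-(methylsulfanyl)phenoxy. Among the compounds with values here, no measured pair shows this change, so no step can be read from the series. The expected step is a 1.0-fold higher number from compound 1 to compound 4 (0.01 log units; within the scatter), none beyond the scatter, in either direction. Compound 4 is estimated at 3.5 nM, with a range from 1.4 nM to 9 nM.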

Compound 4, half-maximal inhibitory concentration: 2.6 nM
Compound 4: the middle estimate sits 1.3-fold (0.13 log units) above what was measured, within the range that was stated.
By their numbers in this assay, from the lowest: compounds 2, 4, 3 and 1 (each within the scatter of the next, the first and the last beyond it).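

Within the data shown here, this is the first single-place change readable: methylsulfanyl in place of fluoro on the aromatic carbon para to a large group gives a 1.3-fold lower number from compound 1 to compound 4 (0.12 log units; within the scatter) in this assay. At this position, the two groups therefore cannot be told apart on this read-out. Nothing measured on these compounds bears on a cause for this result. Still open, as far as these compounds go, is whether an amine, a carboxylic acid or a longer chain at this aromatic carbon would stay within the scatter of compound 1. Also open, from the compounds shown here alone, is whether the same exchange would give a similar step on the core of compound 2.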